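The source may report more compounds than this note shows. Statements on the series, on what has been measured and on what is new or still open speak of the compounds shown alone.

Of the compounds shown here, three have so far been measured in an assay on CHO cells for displacement of a labelled ligand from C-X-C chemokine receptor type 4 (Homo sapiens), with a stated time of 40 min; on this read-out lower numbers stand for stronger inhibition and higher numbers for weaker inhibition. Compound 1 `O=C(NCCCNC1CCCCC1)c1ccc(CNCCCNC2CCCCC2)cc1` gives 699 nM, compound 2 `c1ccc2c(CNCCCNC3CCCCC3)ccc(CNCCCNC3CCCCC3)c2c1` gives 40.8 nM, and compound 3 `O=[N+]([O-])c1cc(CNCCCNC2CCCCC2)cc(CNCCCNC2CCCCC2)c1` gives 147 nM. Compound 3 thus holds the second highest of the three numbers: its nearest neighbour is compound 2, whose lower number lies beyond the usual scatter, and its furthest is compound 1, whose higher number also lies beyond the scatter, so compound 3 sits in the middle of the measured span. The unmeasured compound 4 `CN(C)c1cc(CNCCCNC2CCCCC2)cc(CNCCCNC2CCCCC2)c1` keeps the core of compound 3 and alters one group: dimethylamino in place of nitro on an aromatic carbon. Among the measured compounds shown here, no measured pair shows this particular change, so the data give no direct guide to its size or direction. The expected change in this assay is a 1.2-fold lower number from compound 3 to compound 4 (0.09 log units; within the scatter), a step that is not expected to reach beyond the usual scatter, with only a slight lean toward a lower number. Compound 4 is therefore estimated at 120 nM, within a range from 40 nM to 400 nM.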

Compound 4, half-maximal inhibitory concentration: 119 nM
Compound 4: middle estimate off by 1.0-fold (0.00 log units), on the high side; the range from low to high includes it.
By their numbers in this assay, from the lowest: compound 2; then compounds 4 and 3 (each within the scatter of the next); then compound 1.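

In this assay, placing dimethylamino where nitro stood on this aromatic carbon gives a 1.2-fold lower number from compound 3 to compound 4 (0.09 log units; within the scatter), so on this read-out the two compounds cannot be told apart. Among the compounds shown here, this is the first direct look at a change at this position, and it shows that the oxygen atoms of nitro can leave and the carbon atoms of dimethylamino can enter without the number moving beyond the usual scatter. Nothing at hand says why the number holds across this swap. As far as these compounds go, whether the number would also hold with a carboxylic acid, a primary amine or a longer alkyl chain on this carbon remains open. This single step also cannot show whether the same swap would behave alike on another core, such as that of compound 2.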